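The source may report more compounds than this note shows. Statements on the series, on what has been measured and on what is new or still open speak of the compounds shown alone.

Measured so far:
- compound 1, `O=C(c1cccc(Cl)c1)N1CCC(NS(=O)(=O)c2cc(S(=O)(=O)c3ccccc3)ccc2C(F)(F)F)CC1`, gives 6300 nM
- compound 2, `O=C(c1ccc(C(F)(F)F)cc1)N1CCC(NS(=O)(=O)c2cc(S(=O)(=O)c3ccccc3)ccc2C(F)(F)F)CC1`, gives 6300 nM

In a physicochemical assay for solubility (a higher number here means a more soluble compound, a lower number a less soluble compound), compound 2 stands level with compound 1 at the digits shown: the step of no change at the digits printed from compound 1 to compound 2 (within the scatter) lies within the scatter. The next compound, compound 3, `O=C(c1cccnc1)N1CCC(NS(=O)(=O)c2cc(S(=O)(=O)c3ccccc3)ccc2C(F)(F)F)CC1`, is not yet measured in this assay. It differs from compound 2 by one change, (pyridin-3-yl in place of 4-(trifluoromethyl)phenyl on a carbonyl carbon).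

Going by the values given here, only one measured step exists, and it swaps one carbon-only aromatic ring for another on the same carbonyl carbon; it produced no change beyond the scatter. Among the compounds with values here, no measured step involves a ring with a hetero atom, so nothing in the data speaks directly to the move from 4-(trifluoromethyl)phenyl to pyridin-3-yl. The two measured values sit at the same solubility, which gives a starting point but no trend.

The estimate for compound 3 is therefore anchored on the value of compound 2 with a wide range, and the expected step of a 1.3-fold higher number from compound 2 to compound 3 (0.10 log units; within the scatter) is modest and uncertain in direction. Compound 3 is expected to give about 8000 nM in this assay, with a range from 3000 nM to 25000 nM.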

Compound 3, solubility: 50000 nM
For compound 3 the middle estimate is 6.3-fold (0.80 log units) below the measured one; the measured number lies above the stated range.
By their numbers in this assay, from the lowest: compounds 1 and 2 (each within the scatter of the next); then compound 3.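

In this assay, the group on the carbonyl carbon now proves able to shift the number: pyridin-3-yl in place of 4-(trifluoromethyl)phenyl gives a 7.9-fold higher number from compound 2 to compound 3 (0.90 log units; beyond the scatter), and pyridin-3-yl in place of 3-chlorophenyl gives a 7.9-fold higher number from compound 1 to compound 3 (0.90 log units; beyond the scatter). The earlier pair had shown this position only with two rings of carbon alone, and those two stood level, so this is the first ring with a hetero atom there and the first change at this position to go beyond the scatter. Nothing measured here accounts for the rise.

Each step swaps a ring that carries a substituent for a ring that carries none and also brings in a ring nitrogen, so the compounds shown cannot separate those two parts of the change, whereas a plain phenyl on the same carbonyl carbon could. Also open, on these data alone, is how a ring bearing an amine or a carboxylic acid would compare at this position, and whether pyridin-3-yl would give a similar step on a different core.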